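This account rests on a few compounds, and the source may have more. Where it says the series, first, only, none or still open, it means among the compounds named here.

Measured compounds in an assay on isolated protein for inhibition of Amine oxidase [flavin-containing] B (Homo sapiens), read by fluorescence; a lower number here means a stronger inhibitor, a higher number a weaker inhibitor:

compound 1 `O=C(/C=C/c1ccoc1)c1cc(O)c(O)c([N+](=O)[O-])c1` gives 71400 nM
compound 2 `CC(=O)N1N=C(c2cc(O)c(O)c([N+](=O)[O-])c2)CC1c1ccc(C#N)cc1` gives 83200 nM
compound 3 `CC(=O)N1N=C(c2cc(O)c(O)c([N+](=O)[O-])c2)CC1c1ccoc1` gives 126000 nM

Compound 1 carries the lowest number of the three, yet it is close to the others: compound 2 is only a little higher, by an amount within the scatter, and compound 3, the furthest of the set, also lies within the scatter of compound 1. The three therefore cannot be placed in order of potency from these numbers alone.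

Compound 4 `O=C(/C=C/c1ccco1)c1cc(O)c(O)c([N+](=O)[O-])c1` has not yet been measured. It shares every atom with compound 1 and differs only in how the furan is joined: furan-2-yl in place of furan-3-yl on a double-bonded chain carbon bound to a double-bonded chain carbon.

Among the measured compounds shown here, no measured pair tests exactly this change. The only step shown, a 1.5-fold higher number from compound 2 to compound 3 (0.18 log units; within the scatter), swaps the whole aryl group on a saturated ring carbon of a different core and stays within the scatter. It offers at most an indication that the furan position on this core is not decisive. For compound 4 a step of the same small order is therefore expected in this assay, with no direction beyond the scatter: a 1.1-fold lower number from compound 1 to compound 4 (0.04 log units; within the scatter). The estimate for compound 4 is 65000 nM, with a range from 30000 nM to 150000 nM.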

Compound 4, half-maximal inhibitory concentration: 68200 nM
The estimate for compound 4 lay 1.0-fold (0.02 log units) below the measured number, within the range that was stated.
By their numbers in this assay, from the lowest: compounds 4, 1, 2 and 3 (each within the scatter of the next).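

In this assay, among the compounds shown here, the move of the furan attachment gives a 1.0-fold lower number from compound 1 to compound 4 (0.02 log units; within the scatter) and so provides the first direct reading of this change at this place, where the earlier step had swapped a whole aryl group on a saturated ring carbon of a different core. With the rest of the structure held the same, furan-2-yl and furan-3-yl on a double-bonded chain carbon bound to a double-bonded chain carbon cannot be told apart in this assay, so the point of attachment of the furan does not separate these two compounds. Nothing available here bears on why the two furans read alike.

The compounds shown leave open whether a group other than a furan at this place on the core of compound 1, such as a phenyl ring carrying an amine or a carboxylic acid, would move the number beyond the scatter. Going by these compounds, it also remains open whether furan-2-yl on the saturated ring carbon of the core of compound 3 would read the same as the furan-3-yl found there.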